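A methyl for hydrogen on the central aromatic ring

A few compounds are considered here, and "the series" means these few. Any claim that something is new, unique, unknown or untested is made for them only; others in the source may bear on it.

Compound 3 `CCc1ccc2c(c1)c(=O)c(C(=O)Nc1ccc(Oc3ncnc4[nH]cc(-c5ccccc5)c34)cc1)c(C)n2C` is the unsubstituted member of this small set. In an assay on isolated protein for inhibition of tyrosine-protein kinase receptor UFO (Homo sapiens), read by FRET and Z'-LYTE, with a stated time of 1.5 h (on this read-out lower numbers stand for stronger inhibition and higher numbers for weaker inhibition), compound 3 gives 105 nM, the highest number of the three measured compounds. Compound 1 `CCc1ccc2c(c1)c(=O)c(C(=O)Nc1ccc(Oc3ncnc4[nH]cc(-c5ccccc5)c34)c(F)c1)c(C)n2C` gives 6 nM, and compound 2 `CCc1ccc2c(c1)c(=O)c(C(=O)Nc1ccc(Oc3ncnc4[nH]cc(-c5ccccc5)c34)cc1F)c(C)n2C` gives 30 nM; both carry a fluoro on an aromatic carbon where compound 3 carries hydrogen. Removing that fluoro weakens inhibition in both cases: an 18-fold higher number from compound 1 to compound 3 (1.24 log units; beyond the scatter), and a 3.5-fold higher number from compound 2 to compound 3 (0.54 log units; beyond the scatter).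

Compound 4 `CCc1ccc2c(c1)c(=O)c(C(=O)Nc1ccc(Oc3ncnc4[nH]cc(-c5ccccc5)c34)c(C)c1)c(C)n2C` has not yet been measured in this assay. It differs from compound 3 by methyl in place of hydrogen on an aromatic carbon. Among the compounds with values here, no measured step introduces a methyl, so the two fluoro steps are the only ones that bear on it, and they show that substituting a hydrogen on an aromatic carbon of this ring can lower the number by a large or modest amount. A methyl is a different group, so the transfer is uncertain, but a step towards lower numbers is expected. The estimated change for compound 4 is a 2.6-fold lower number from compound 3 to compound 4 (0.42 log units; beyond the scatter) in this assay. Compound 4 is therefore expected to give about 40 nM in this assay, with a plausible range from 10 nM to 160 nM.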

Compound 4, half-maximal inhibitory concentration: 1120 nM
Compound 4: the middle estimate sits 28-fold (1.45 log units) below what was measured; the whole stated range lies below it.
By their numbers in this assay, from the lowest: compound 1; then compound 2; then compound 3; then compound 4.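

In this assay, within the data shown here, the carbon ortho to a large group and meta to a large group does not respond to every substituent in the same direction: methyl in place of hydrogen gives an 11-fold higher number from compound 3 to compound 4 (1.03 log units; beyond the scatter) in the opposite direction from what fluoro at this position gives, since the earlier steps showed that losing fluoro raised the number. Placing methyl where compound 1 carries fluoro gives a 190-fold higher number from compound 1 to compound 4 (2.27 log units; beyond the scatter) on the same carbon, the largest step in the set, so the outcome here depends on which group enters and not simply on hydrogen being replaced. Nothing presented here explains why methyl and fluoro part so sharply at this carbon.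

The compounds shown leave open whether other groups at this carbon, such as chloro, methoxy or ethyl, follow methyl or fluoro. They also leave open whether methyl on the aromatic carbon that carries fluoro in compound 2 would raise the number as it does here.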